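The compounds below may be only part of what the source reports. "The series", "measured", "known", "first", "only" and "open" are said of these compounds alone.

In an in vivo ADME assay on the whole organism (strain BALB/c) for pharmacokinetics, with Mus musculus as the target, read by LC-MS, at a dose of 5 mg/kg by the oral route (a higher number here means that a larger share of the oral dose reaches the circulation, a lower number that a smaller share of the oral dose reaches the circulation), compound 1 `CCCS(=O)(=O)c1cccc(C#Cc2cc(Cl)ccc2OCC(=O)O)c1` gives 37% and compound 2 `CC(C)c1ccc(S(C)(=O)=O)cc1C#Cc1cc(C#N)ccc1OCC(=O)O` gives 26% in the same test. Compound 3 `COCCNS(=O)(=O)c1ccc(C)c(C#Cc2cc(Cl)ccc2OCC(=O)O)c1` stands at 33% within the scatter of both others. Compound 4 `Cc1ccc(S(=O)(=O)N2CCOCC2)cc1C#Cc1cc(Cl)ccc1OCC(=O)O` has not yet been measured in this assay and differs from compound 3 on a sulfonyl sulfur, where morpholin-4-yl in place of (2-methoxyethyl)amino on a sulfonyl sulfur is the whole change. For the measured compounds named here, no step between measured compounds shows this kind of change, so the expectation stays with compound 3 at 33% as its starting point, with no direction favoured. The expected step of a number 1 percentage points lower from compound 3 to compound 4 (within the scatter) is none beyond the scatter. For compound 4 the estimate is 32% as the expected middle, with an estimated range from 18% to 47% for repeat measurements.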

Compound 4, oral bioavailability: 48%
Estimate against measurement, compound 4: 16 percentage points below; the measured number lies above the stated range.
By their numbers in this assay, from the lowest: compounds 2, 3 and 1 (each within the scatter of the next, the first and the last beyond it); then compound 4.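

In this assay, morpholin-4-yl in place of (2-methoxyethyl)amino on a sulfonyl sulfur gives a number 15 percentage points higher from compound 3 to compound 4 (beyond the scatter), so this position can move oral bioavailability by more than the usual scatter, which no earlier comparison could show. No measurement at hand explains the step. The compounds shown leave open whether the ring or the lost hydrogen-bond donor matters, which dimethylamino or piperidin-1-yl on the same sulfur would separate. They also leave open whether the step would hold on a core carrying a nitrile.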